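A Thiophene Replaces the Cyclopropylethynyl Group

The source may report more compounds than this note shows. Statements on the series, on what has been measured and on what is new or still open speak of the compounds shown alone.

Compound 1 `Nc1ncnn2c([C@@H]3O[C@H](CO)[C@@H](O)[C@H]3O)cc(C#CC3CC3)c12`: 80 nM
Compound 2 `Nc1ncnn2c([C@@H]3O[C@H](CO)[C@@H](O)[C@H]3O)cc(C#Cc3cccs3)c12`: 26600 nM
Compound 3 `Nc1ncnn2c([C@@H]3O[C@H](CO)[C@@H](O)[C@H]3O)cc(-c3ccc(Cl)cc3)c12`: 45900 nM

In a functional assay on NCI-H460 cells (Homo sapiens) for antiproliferative activity, with a stated time of 72 h (on this read-out lower numbers stand for stronger inhibition and higher numbers for weaker inhibition), compound 1 gives 80 nM and stands lowest of the three numbers; its nearest neighbour is compound 2, which in this assay gives 26600 nM, and the furthest is compound 3, which in this assay gives 45900 nM.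

Compound 4 `Nc1ncnn2c([C@@H]3O[C@H](CO)[C@@H](O)[C@H]3O)cc(-c3ccsc3)c12` has not been measured. It differs from compound 1 in one place: thiophen-3-yl in place of 2-cyclopropylethynyl on an aromatic carbon.

Within the data shown here, two measured steps bear on this change. The first, a 330-fold higher number from compound 1 to compound 2 (2.52 log units; beyond the scatter), replaces the cyclopropyl on the triple-bonded carbon with an aromatic ring. The second, a 570-fold higher number from compound 1 to compound 3 (2.76 log units; beyond the scatter), removes the triple bond altogether and puts an aromatic ring directly on the aromatic carbon, as the change to compound 4 does. Both steps are large and point the same way, so a large rise in this assay is expected for compound 4, of about a 380-fold higher number from compound 1 to compound 4 (2.57 log units; beyond the scatter). Compound 4 is therefore estimated at 30000 nM in this assay, with a range from 8000 nM to 100000 nM.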

Compound 4, half-maximal inhibitory concentration: 35600 nM
Compound 4: middle estimate off by 1.2-fold (0.07 log units), on the low side, within the range that was stated.
By their numbers in this assay, from the lowest: compound 1; then compounds 2, 4 and 3 (each within the scatter of the next).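

In this assay, the step of a 450-fold higher number from compound 1 to compound 4 (2.65 log units; beyond the scatter) shows that thiophen-3-yl on this aromatic carbon does not preserve the low number of compound 1, even though the entering and leaving groups have the same heavy-atom count. The remaining steps, a 1.3-fold lower number from compound 3 to compound 4 (0.11 log units; within the scatter) and a 1.3-fold higher number from compound 2 to compound 4 (0.13 log units; within the scatter), both lie within the scatter, so compounds 2, 3 and 4 cannot be told apart here, whether their aromatic ring sits directly on the core or on a triple bond. Among these four compounds, only compound 1, with 2-cyclopropylethynyl, stands apart.

No measurement given here explains this gap. From the compounds shown here alone, it remains open whether the low number needs the cyclopropyl ring, the triple bond or both, as a directly attached cyclopropyl or a tert-butyl on the triple bond would test.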